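The compounds below may be only part of what the source reports. "The series", "measured", "known", "first", "only" and "open" are said of these compounds alone.

Three compounds set the scene. Compound 1 `C[C@H]1C[C@H]1C(=O)N1CC2CNCC2C1` gives 19000 nM in an assay on SHEP1 cells for agonist activity at Neuronal acetylcholine receptor; alpha4/beta2 (Homo sapiens), read by FLIPR and calcium flux; a lower number here means that less compound is needed, a higher number that more compound is needed for the effect. Compound 2 `COC(=O)[C@H]1C[C@H]2CNC[C@H]2C1` gives 1200 nM in this assay. Compound 3 `O=C(C1CC1)[C@H]1C[C@@H]2CNC[C@@H](C2)C1` gives 7100 nM in this assay, which places it second highest of the three, closer to compound 1 than to compound 2, though each of those gaps lies beyond the usual scatter. No two of these compounds differ in only one place, so none of these gaps can be read as a single structural step.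

Compound 4 `CNC(=O)[C@H]1C[C@@H]2CNC[C@@H](C2)C1` differs from compound 3 in a single place: methylamino in place of cyclopropyl on a carbonyl carbon. Within the data shown here, nothing among the measured compounds isolates this exchange on the shared core of compound 3. The nearest hint is that compound 1, which also carries an amide-type carbonyl, gives a high number, while compound 2, with a different carbonyl substituent and a different core, gives the lowest. On that thin basis the step from compound 3 to compound 4 is expected to be small, a 1.4-fold lower number from compound 3 to compound 4 (0.15 log units; within the scatter), and possibly within the scatter. Compound 4 is therefore estimated at 5000 nM, with a range from 1500 nM to 20000 nM.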

Compound 4, half-maximal effective concentration: 2000 nM
The estimate for compound 4 lay 2.5-fold (0.40 log units) above the measured number, within the range that was stated.
By their numbers in this assay, from the lowest: compounds 2 and 4 (each within the scatter of the next); then compound 3; then compound 1.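

Among these compounds, on the shared core, the group on a carbonyl carbon whose other neighbour is a saturated ring carbon does affect the result in this assay: methylamino in place of cyclopropyl gives a 3.6-fold lower number from compound 3 to compound 4 (0.55 log units; beyond the scatter) as a modest step and the first single-place change that can be read here. With this exchange, the three-membered carbon ring of cyclopropyl leaves and the nitrogen and hydrogen-bond donor of methylamino enter, so several features change at once. Nothing shown here separates these features or accounts for the step.

Going by these compounds, whether ethylamino, dimethylamino or a plain amino group on the same carbonyl carbon would give a similar number remains open. This single exchange also leaves open whether the same change would give a similar step on the core of compound 1 or of compound 2.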